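Fluorophenyl for cyclohexyl on the enone chain

A few compounds are considered here, and "the series" means these few. Any claim that something is new, unique, unknown or untested is made for them only; others in the source may bear on it.

In a functional assay on HeLa cells (Homo sapiens) for inhibition, read by sulforhodamine B assay, with a stated time of 48 h (a higher number here means a weaker inhibitor of growth, a lower number a stronger inhibitor of growth), compound 2 `CC(=O)OC/C(=C\C1CCCCC1)C(=O)c1ccccc1` gives 21000 nM, and compound 1 `O=C(/C(=C/C1CCCCC1)CCl)c1ccccc1` gives 30000 nM. For the measured compounds named here, these are the only two numbers so far, and the step of a 1.4-fold lower number from compound 1 to compound 2 (0.15 log units; within the scatter) lies within the scatter, so compound 2 stands level with compound 1 rather than apart from it. Compound 3 `CC(=O)OC/C(=C\c1ccccc1F)C(=O)c1ccccc1` differs from compound 2 by 2-fluorophenyl in place of cyclohexyl on a double-bonded chain carbon bound to a double-bonded chain carbon. Going by the values given here, the single measured step concerns a different position, so no measured step bears on this change and no direction beyond the scatter is indicated. Compound 3 is therefore expected to stay near compound 2, the estimated step being a 1.1-fold lower number from compound 2 to compound 3 (0.02 log units; within the scatter). The estimate for compound 3 is 20000 nM, with a range from 5000 nM to 70000 nM.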

Compound 3, concentration for 50% growth inhibition: 22000 nM
The estimate for compound 3 lay 1.1-fold (0.04 log units) below the measured number; the measured number falls inside the stated range.
By their numbers in this assay, from the lowest: compounds 2, 3 and 1 (each within the scatter of the next).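

In this assay the exchange of cyclohexyl for 2-fluorophenyl on a double-bonded chain carbon bound to a double-bonded chain carbon gives a 1.0-fold higher number from compound 2 to compound 3 (0.02 log units; within the scatter) and so leaves compound 3 level with compound 2. For the compounds shown here, this is the first reading at this position, where the aromatic and the non-aromatic six-membered ring do not separate; the earlier step covered only the saturated chain carbon. No measurement available here accounts for this result. Still open, as far as these compounds go, is whether an amine or a carboxylic acid on this ring would move the number beyond the scatter.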